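This account rests on a few compounds, and the source may have more. Where it says the series, first, only, none or still open, it means among the compounds named here.

Measured compounds:
Compound 1 `O=C(CN1CCC(c2cccc[n+]2[O-])CC1)Nc1cccc(F)c1` gives 70% in a functional assay on HEK293 cells for agonist activity at D(4) dopamine receptor (Homo sapiens), read by FLIPR; on this read-out higher numbers stand for larger maximal responses and lower numbers for smaller maximal responses.
Compound 2 `Cc1cccc(Cl)c1NC(=O)CN1CCC(c2ccccn2)CC1` gives 70% in this assay.
Compound 3 `Cc1cccc(C(=O)NCN2CCC(c3cccc[n+]3[O-])CC2)c1` gives 77% in this assay.

Compound 1 stands level with compound 2 at the digits shown, and compound 3 differs from compound 1 only within the scatter, so the three efficacies form a tight cluster. Compound 4 `CSc1cccc(NC(=O)CN2CCC(c3cccc[n+]3[O-])CC2)c1` differs from compound 1 in one place: methylsulfanyl in place of fluoro on an aromatic carbon. Among the measured compounds shown here, no pair of measured compounds carries this exchange, so nothing measured tells its size. Compound 4 is therefore expected to stay in the same cluster, and the step of a number 2 percentage points higher from compound 1 to compound 4 (within the scatter) is expected to lie within the scatter rather than beyond it. The estimate for compound 4 is 72%, with a range from 58% to 86%.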

Compound 4, largest response reached (reported as efficacy), in percent of the reference or control that the assay uses: 56%
The estimate for compound 4 lay 16 percentage points above the measured number; the measured number lies below the stated range.
By their numbers in this assay, from the lowest: compound 4; then compounds 1, 2 and 3 (each within the scatter of the next).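

In this assay, putting methylsulfanyl in place of fluoro on this aromatic carbon gives a number 14 percentage points lower from compound 1 to compound 4 (beyond the scatter), which shows that the maximal response depends on the group held at this position. Among the compounds shown here, this is the first measured step between compounds that differ in one place, so the earlier compounds could not show this dependence. Nothing available explains the size of this step. On these data alone, whether methoxy or an amine at this position would also lower the response remains open, as does whether the same exchange would give a similar step on another core.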